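This account rests on a few compounds, and the source may have more. Where it says the series, first, only, none or still open, it means among the compounds named here.

In an assay on CHO cells for antagonist activity at transient receptor potential cation channel subfamily V member 1 (Homo sapiens), read by FLIPR (a lower number here means a stronger inhibitor, a higher number a weaker inhibitor), compound 1 `CCCN(CCC)c1cc(C(F)(F)F)ccc1CNC(=O)C(C)c1ccc(NS(C)(=O)=O)c(F)c1` gives 0.3 nM. Compound 2 `CC(C(=O)NCc1ccc(C(F)(F)F)cc1OCc1ccccc1)c1ccc(NS(C)(=O)=O)c(F)c1` gives 0.9 nM in this assay, and compound 3 `CC(C)CCSc1cc(C(F)(F)F)ccc1CNC(=O)C(C)c1ccc(NS(C)(=O)=O)c(F)c1` gives 1.4 nM. Going by the values given here, as written, compound 3 stands at the top of the three numbers, yet its gap to compound 2 is within the scatter, and only the step of a 4.7-fold higher number from compound 1 to compound 3 (0.67 log units; beyond the scatter) lies beyond it. The three compounds differ at a single aromatic carbon of the shared core, where the steps were a 3.0-fold higher number from compound 1 to compound 2 (0.48 log units; beyond the scatter) and a 1.6-fold higher number from compound 2 to compound 3 (0.19 log units; within the scatter).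

Compound 4 `CC(C(=O)NCc1ccc(C(F)(F)F)cc1-c1cccc(Cl)c1)c1ccc(NS(C)(=O)=O)c(F)c1` changes that same position: 3-chlorophenyl in place of isopentylsulfanyl on an aromatic carbon. The measured steps that bear on this are the two earlier replacements at that aromatic carbon, a 4.7-fold higher number from compound 1 to compound 3 (0.67 log units; beyond the scatter) and a 1.6-fold higher number from compound 2 to compound 3 (0.19 log units; within the scatter), one modest and one within the scatter; each of the three groups tried there keeps the number low. Among the compounds with values here, none of the measured compounds carries a six-membered aromatic ring directly on that carbon, so the size of the new step is not fixed by any precedent. The expected step of a 1.1-fold higher number from compound 3 to compound 4 (0.03 log units; within the scatter) is accordingly small and could fall in either direction. Compound 4 is estimated at 1.5 nM in this assay, with a range from 0.4 nM to 6 nM.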

Compound 4, inhibition constant: 1 nM
The estimate for compound 4 lay 1.5-fold (0.18 log units) above the measured number; measured number inside the range.
By their numbers in this assay, from the lowest: compound 1; then compounds 2, 4 and 3 (each within the scatter of the next).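

In this assay, a six-membered aromatic ring carried directly on this aromatic carbon falls in the same narrow band as the isopentylsulfanyl and benzyloxy groups: a 1.4-fold lower number from compound 3 to compound 4 (0.15 log units; within the scatter) and a 1.1-fold higher number from compound 2 to compound 4 (0.05 log units; within the scatter) are both small, so this position accepts a group with no flexible chain before its ring and with 0 hydrogen-bond acceptors. Dipropylamino stays the only group set apart from all the others, since a 3.3-fold higher number from compound 1 to compound 4 (0.52 log units; beyond the scatter) adds a third modest step beyond the scatter to those already seen for benzyloxy and isopentylsulfanyl. No measurement at hand explains these steps or accounts for the separate place of dipropylamino.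

Going by these compounds, what the chlorine adds remains open, and plain phenyl, 4-chlorophenyl or 3-methoxyphenyl at this carbon would be needed to separate the ring from its substituent. On these data alone, it is also open whether the lower number belongs to dipropylamino alone or extends to other amines, such as dimethylamino, diethylamino or a morpholine attached through its nitrogen.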